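Lengthening a side chain on a chlorinated purine amide

The compounds below may be only part of what the source reports. "The series", "measured", "known", "first", "only" and "open" are said of these compounds alone.

Of the compounds shown here, two of a shared core have been measured so far. Compound 1, `O=C(O)CN(c1nc(Cl)nc2c1ncn2C1CCCCO1)C1CC1`, carries a free acid; in a functional assay on the whole organism with Mus musculus as the target, with a stated time of 90 min, at a dose of 25 umol/kg by the oral route (a higher number here means a stronger effect of the compound at the dose given, a lower number a weaker effect), compound 1 gives 8.22%. Compound 2, `NC(=O)C[C@H](NC(=O)CN(c1nc(Cl)nc2c1ncn2C1CCCCO1)C1CC1)C(=O)OCc1ccccc1`, joins that acid to an amino acid ester bearing a carbamoyl group; in this assay compound 2 gives 35%. Compound 2 thus stands higher than compound 1, and the gap between the two lies beyond the scatter of repeated measurements.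

Compound 3, `NC(=O)CC[C@H](NC(=O)CN(c1nc(Cl)nc2c1ncn2C1CCCCO1)C1CC1)C(=O)OCc1ccccc1`, has not yet been measured. It differs from compound 2 in one place: carbamoylmethyl in place of carbamoyl on a saturated chain carbon, two bonds along the chain from an amide-type nitrogen and a carbonyl carbon. Cut one bond further out, the same difference reads carbamoylmethyl to 2-carbamoylethyl. Going by the values given here, no measured pair shows this change, so nothing measured tells how far it will move the read-out.

With the amino acid ester kept in place, compound 3 is expected to stay close to compound 2, a step of a number 2 percentage points lower from compound 2 to compound 3 (within the scatter) in this assay, within the scatter. Compound 3 is therefore estimated at 33%, with a range from 15% to 55%.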

Compound 3, a percentage reported as activity, at one dose (the size of the read-out at that dose, not a potency): 37.8%
The estimate for compound 3 lay 4.8 percentage points below the measured number, and the stated range covers the measured number.
By their numbers in this assay, from the lowest: compound 1; then compounds 2 and 3 (each within the scatter of the next).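

Putting carbamoylmethyl in place of carbamoyl on a saturated chain carbon, two bonds along the chain from an amide-type nitrogen and a carbonyl carbon, gives in this assay a step of a number 2.8 percentage points higher from compound 2 to compound 3 (within the scatter) at this one oral dose. Going by these compounds alone, this is the first pair that differs at this position, and it shows that the longer carbamoylmethyl group is tolerated here, with the read-out staying within the scatter of the value for the shorter carbamoyl group. Nothing measured here explains why the read-out holds across this change.

The two compounds cover only these two chain lengths, so they give no reading on a longer chain ending in the same amide, or on a carboxylic acid or an amine at the end of the chain in place of that amide. Because each value is a percentage at a single dose, not a potency, the pair also leaves open whether the two compounds would still match at other doses.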